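Swapping a fluorophenyl for a methylphenyl on the amine

This account rests on a few compounds, and the source may have more. Where it says the series, first, only, none or still open, it means among the compounds named here.

Of the compounds shown here, three sharing one core have been tested in a functional assay on MGC-803 cells (Homo sapiens) for inhibition, read by sulforhodamine B assay; on this read-out lower numbers stand for stronger inhibition and higher numbers for weaker inhibition. Compound 1 `Cc1ccc(NC2=CC(=O)c3c(nc4n3[C@H]3OC[C@@H](O)[C@H]3OC4)C2=O)cc1` gives 1550 nM. Compound 2 `O=C1C=C(Nc2cccc(F)c2)C(=O)c2c1nc1n2[C@H]2OC[C@@H](O)[C@H]2OC1` gives 2180 nM, which is the higher of the two plain numbers, though its gap to compound 1 lies within the scatter. Compound 3 `O=C1C(N2CCCCC2)=CC(=O)c2c1nc1n2[C@H]2OC[C@@H](O)[C@H]2OC1` gives only a limit of > 4000 nM, so its number is not known. For the measured compounds named here, the one measured step, an at least 2.5-fold higher number from compound 1 to compound 3 (0.41 log units; beyond the scatter), is at least modest and runs in the weaker direction; it is the only change with an anchor here, as the limit of > 4000 nM in this assay, at which 1 of the 3 values shown sits, shows.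

Compound 4 `Cc1ccc(NC2=CC(=O)c3nc4n(c3C2=O)[C@H]2OC[C@@H](O)[C@H]2OC4)cc1` differs from compound 2 by 4-methylphenyl in place of 3-fluorophenyl on an amine nitrogen. Going by the values given here, no measured step covers this swap, and the two aryl groups are alike in size and count. Compound 1 does carry a 4-methylphenyl on an amine nitrogen, and its value sits close to compound 2. The change is therefore expected to be a 1.2-fold lower number from compound 2 to compound 4 (0.08 log units; within the scatter), within the scatter. Compound 4 is estimated at 1800 nM, between 700 nM and 4500 nM.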

Compound 4, half-maximal inhibitory concentration: 1420 nM
Compound 4: the middle estimate sits 1.3-fold (0.10 log units) above what was measured, within the range that was stated.
By their numbers in this assay, from the lowest: compounds 4, 1 and 2 (each within the scatter of the next). At a limit, above all of these: compound 3.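

In this assay the step from one aryl group to the other is small: a 1.5-fold lower number from compound 2 to compound 4 (0.19 log units; within the scatter), so on this read-out 3-fluorophenyl and 4-methylphenyl on this amine nitrogen cannot be told apart. The earlier compounds shown here offered no measured step that kept an aromatic ring on this nitrogen, and this pair shows that changing what the ring carries, and where, can leave the number within the usual scatter, at least for these two groups. Nothing measured here speaks to why the two groups give such similar numbers.

Two small groups say little about the ring as a whole. A carboxylic acid or a dimethylamino group on the phenyl ring, or a benzyl group on the amine nitrogen, might still move the number beyond the scatter, and the compounds shown cannot say in which direction.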